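A Fluorinated Anilino Variant of Compound 1

A few compounds are considered here, and "the series" means these few. Any claim that something is new, unique, unknown or untested is made for them only; others in the source may bear on it.

Compound 1 `Cc1ccc(NC2=CC(=O)c3nc4n(c3C2=O)[C@H]2OC[C@@H](O)[C@H]2OC4)cc1` carries a (4-methylphenyl)amino group on a double-bonded ring carbon of the shared core. In a functional assay on HeLa cells (Homo sapiens) for inhibition, read by sulforhodamine B assay (a lower number here means a stronger inhibitor, a higher number a weaker inhibitor), compound 1 gives 3860 nM, the lower of the two numbers recorded, although its gap to compound 2 lies within the scatter. Compound 2 `COc1ccccc1NC1=CC(=O)c2c(nc3n2[C@H]2OC[C@@H](O)[C@H]2OC3)C1=O`, with a (2-methoxyphenyl)amino group at that carbon, gives 7460 nM in this assay. Compound 3 `CCCN(CCC)C1=CC(=O)c2c(nc3n2[C@H]2OC[C@@H](O)[C@H]2OC3)C1=O`, which bears a dipropylamino group instead, reaches only a limit in this assay, reported as > 16000 nM. Among the measured compounds shown here, the single measured step, an at least 2.1-fold higher number from compound 2 to compound 3 (0.33 log units; beyond the scatter), thus describes the replacement of an arylamino group by a dialkylamino one, and its size is known only through (the limit of > 16000 nM in this assay, at which 1 of the 3 values shown sits).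

Compound 4 `O=C1C=C(Nc2cccc(F)c2)C(=O)c2c1nc1n2[C@H]2OC[C@@H](O)[C@H]2OC1` differs from compound 1 by 3-fluorophenyl in place of 4-methylphenyl on an amine nitrogen. For the measured compounds named here, no measured step covers an exchange of one substituted phenyl for another on that nitrogen. Compound 1 and compound 2, which differ only in the substituted phenyl on that nitrogen, give numbers within the scatter of each other. On that basis the expected step of a 1.2-fold higher number from compound 1 to compound 4 (0.07 log units; within the scatter) is small, not beyond the scatter, in either direction. Compound 4 is therefore estimated at 4500 nM, with a range from 1800 nM to 12000 nM.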

Compound 4, half-maximal inhibitory concentration: 6440 nM
Beside the measured number, compound 4's estimate is 1.4-fold (0.16 log units) below it; measured number inside the range.
By their numbers in this assay, from the lowest: compounds 1, 4 and 2 (each within the scatter of the next). At a limit, above all of these: compound 3.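

The exchange gives a 1.7-fold higher number from compound 1 to compound 4 (0.22 log units; within the scatter) in this assay and so adds a listed step in which one substituted phenyl replaces another on the amine nitrogen, something the earlier step, from an arylamino to a dialkylamino group, did not cover. Here both the substituent and its place on the phenyl ring change while the heavy-atom count of the group stays the same, yet the step stays within the scatter, so this change does not separate compound 1 from compound 4 in this assay. With compound 2 also within the scatter of compound 4, the three arylamino compounds form one group that cannot be ordered, and the data shown give no measured property that would account for this result.

From the compounds shown here alone, what remains open is whether any change on the phenyl ring can move the number beyond the scatter, for example a carboxylic acid, a nitrile or a second fluorine. Going by these compounds, it is also open how a propylamino group with a single chain, or a benzylamino group, would compare with the arylamino compounds and with compound 3.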